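Azetidine urea replacing cyclobutyl amide in the bicyclic series

The compounds below may be only part of what the source reports. "The series", "measured", "known", "first", "only" and "open" are said of these compounds alone.

Measured so far:
compound 1, `CCn1c(-c2ccc(C(F)(F)F)nc2)nc2c(O[C@H]3CCN(C(=O)N4CC(OC)C4)C3)ncnc21` — 1.7 mL/min/kg
compound 2, `CCn1c(-c2cnc(C)nc2)nc2c(O[C@H]3CCN(C(=O)[C@H]4C[C@@H](OC)C4)C3)ncnc21` — 3.8 mL/min/kg

In an ADME assay on the whole organism (Rattus norvegicus, strain Wistar Han) for pharmacokinetics (on this read-out lower numbers stand for slow clearance and higher numbers for fast clearance), compound 1 gives 1.7 mL/min/kg. Compound 2 gives 3.8 mL/min/kg, the higher of the two numbers; the gap to compound 1 lies beyond the usual scatter.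

Compound 3, `CCn1c(-c2cnc(C)nc2)nc2c(O[C@H]3CCN(C(=O)N4CC(OC)C4)C3)ncnc21`, has not been measured. It differs from compound 2 in one place: 3-methoxyazetidin-1-yl in place of 3-methoxycyclobutyl on a carbonyl carbon. Among the measured compounds shown here, no measured pair shows this change directly, so its effect is not known.

Compound 3 is expected to read somewhat lower than compound 2, a small step, a 1.5-fold lower number from compound 2 to compound 3 (0.18 log units; within the scatter), close to the scatter. The estimate for compound 3 is 2.5 mL/min/kg, with a range from 1.2 mL/min/kg to 5 mL/min/kg.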

Compound 3, clearance in the Rattus norvegicus assay: 4 mL/min/kg
Beside the measured number, compound 3's estimate is 1.6-fold (0.20 log units) below it, within the range that was stated.
By their numbers in the Rattus norvegicus assay, from the lowest: compound 1; then compounds 2 and 3 (each within the scatter of the next).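

In the Rattus norvegicus assay, 3-methoxyazetidin-1-yl in place of 3-methoxycyclobutyl on a carbonyl carbon gives a 1.1-fold higher number from compound 2 to compound 3 (0.02 log units; within the scatter), whereas 2-methylpyrimidin-5-yl in place of 6-(trifluoromethyl)pyridin-3-yl gives a 2.4-fold higher number from compound 1 to compound 3 (0.37 log units; beyond the scatter), so in this set the aryl change, not the carbonyl substituent, is the one that separates clearance. In a physicochemical assay for lipophilicity, read by HPLC (a higher number here means a more lipophilic compound, a lower number a more polar compound), compound 2 reads 1 and compound 3 reads 0.9, which is also within the scatter. No measurement available here explains either step.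

As far as these compounds go, whether the azetidine and cyclobutyl groups also match alongside 6-(trifluoromethyl)pyridin-3-yl stays open. So does the effect of a hydroxyl or a fluorine in place of the methoxy group on the azetidine.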